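The compounds below may be only part of what the source reports. "The series", "measured", "known", "first", "only" and "open" are said of these compounds alone.

Working notes on the chain-extension series.

Compound 1 `Cc1ccccc1OS(=O)(=O)c1cccc(NC(=O)NCCCCl)c1` and compound 2 `CCc1ccccc1OS(=O)(=O)c1cccc(NC(=O)NCCCCl)c1` share one core and differ only in the group on the phenyl ester. In a functional assay on HT-29 cells (Homo sapiens) for cytotoxicity, read by sulforhodamine B assay, with a stated time of 48 h (on this read-out higher numbers stand for weaker inhibition and lower numbers for stronger inhibition), compound 1 gives 21000 nM; in this assay compound 2 gives 23000 nM. Among the measured compounds shown here, the single recorded step, a 1.1-fold higher number from compound 1 to compound 2 (0.04 log units; within the scatter), is a methyl in place of hydrogen on a saturated chain carbon bound to an aromatic carbon, and it moved nothing beyond the scatter. On the two numbers shown, compound 2 stands at the higher end, with compound 1 as its only neighbour and within the scatter of it.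

Compound 3 `CCCc1ccccc1OS(=O)(=O)c1cccc(NC(=O)NCCCCl)c1` takes the same direction one bond further out: methyl in place of hydrogen on a saturated chain carbon, two bonds along the chain from an aromatic carbon. For the measured compounds named here, the only step that bears on it is the one from compound 1 to compound 2, which was flat, so no step beyond the scatter is expected in this assay in either direction. For compound 3 the expected value is 24000 nM, range 12000 nM to 50000 nM, which means an expected step of a 1.0-fold higher number from compound 2 to compound 3 (0.02 log units; within the scatter).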

Compound 3, half-maximal inhibitory concentration: 14000 nM
Estimate against measurement, compound 3: 1.7-fold (0.23 log units) above; measured number inside the range.
By their numbers in this assay, from the lowest: compounds 3, 1 and 2 (each within the scatter of the next).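

Going from 2-ethylphenyl to 2-propylphenyl in this assay gives a 1.6-fold lower number from compound 2 to compound 3 (0.22 log units; within the scatter), and the whole extension, read with ethyl in place of hydrogen on the saturated chain carbon bound to an aromatic carbon, gives a 1.5-fold lower number from compound 1 to compound 3 (0.18 log units; within the scatter). Among the compounds shown here, both steps lie within the scatter, so this position now accepts a second added carbon as well as the first without a step that can be read, and methyl, ethyl and propyl show no trend with chain length. No measurement bears on why the chain leaves the number within the scatter.

The compounds shown leave open whether a butyl or longer chain, or an amine or a carboxylic acid in place of the propyl group, would give a step beyond the scatter in this assay.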